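The source may report more compounds than this note shows. Statements on the series, on what has been measured and on what is new or still open speak of the compounds shown alone.

Measured so far in a functional assay on CHO cells for antagonist activity at C-C chemokine receptor type 4 (Homo sapiens), read by GTPgammaS binding; a lower number here means a stronger inhibitor, a higher number a weaker inhibitor:
compound 1 `CC(=O)NCc1cccc(Cn2nc(NS(=O)(=O)c3ccc(Cl)s3)c3c(O)cccc32)c1`, 12.6 nM
compound 2 `COc1cccc2c1c(NS(=O)(=O)c1ccc(Cl)s1)nn2Cc1cccc(CNC(=O)C2CCCO2)c1`, 39.8 nM

Among the measured compounds shown here, compound 2 gives the higher of the two numbers in this assay; compound 1 sits lower by a gap beyond the scatter, and no single-point step links the two.

Compound 3 `COc1cccc2c1c(NS(=O)(=O)c1ccc(Cl)s1)nn2Cc1cccc(CNC(=O)C(C)(C)N)c1` differs from compound 2 by 1-amino-1-methylethyl in place of oxolan-2-yl on a carbonyl carbon. For the measured compounds named here, no measured pair shows this change, so its size and direction are unknown. For compound 3 a step within or just beyond the scatter from compound 2 is expected, direction open, giving an estimated 1.2-fold lower number from compound 2 to compound 3 (0.09 log units; within the scatter). Compound 3 is thus expected near 32 nM, plausibly between 8 nM and 130 nM.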

Compound 3, half-maximal inhibitory concentration: 15.9 nM
Compound 3: the middle estimate sits 2.0-fold (0.30 log units) above what was measured; the measured number falls inside the stated range.
By their numbers in this assay, from the lowest: compounds 1 and 3 (each within the scatter of the next); then compound 2.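

At this carbonyl carbon, 1-amino-1-methylethyl in place of oxolan-2-yl gives a 2.5-fold lower number from compound 2 to compound 3 (0.40 log units; beyond the scatter) in this assay and shows that the position responds to the group it carries. A ring at this place is not needed for a number of this size, as compound 3 has none. The change swaps ring for open chain and ring oxygen for amino nitrogen at once, so this step cannot separate the two. Isopropyl or aminomethyl on the same carbonyl carbon would test the amine and the branching separately, and nothing measured gives a reason for the step.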